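This account rests on a few compounds, and the source may have more. Where it says the series, first, only, none or still open, it means among the compounds named here.

Measured in a functional assay on A549 cells (Homo sapiens) for inhibition, read by MTT assay, with a stated time of 72 h; a higher number here means a weaker inhibitor, a lower number a stronger inhibitor:
- compound 1 `COc1cc2c(Oc3ccc(NC(=O)c4nn(-c5ccccc5C)cc(C)c4=O)cc3)ccnc2cc1OCCCCCCC(=O)NO`: 3130 nM
- compound 2 `COc1cc2c(Oc3ccc(NC(=O)c4nn(-c5ccccc5C)cc(C)c4=O)c(F)c3)ccnc2cc1OCCCCCCC(=O)NO`: 4280 nM

In this assay, compound 2 gives 4280 nM, within the scatter of compound 1 at 3130 nM. Compound 3 `COc1cc2c(Oc3ccc(NC(=O)c4nn(-c5ccccc5C)ccc4=O)c(F)c3)ccnc2cc1OCCCCCCC(=O)NO` differs from compound 2 by hydrogen in place of methyl on an aromatic carbon. For the measured compounds named here, the only measured step, a 1.4-fold higher number from compound 1 to compound 2 (0.14 log units; within the scatter), is a different change, fluoro in place of hydrogen, so it offers only a loose guide. Going by the values given here, no measured step removes this methyl. A shift beyond the scatter in this assay is therefore not expected, and the estimated step is a 1.1-fold lower number from compound 2 to compound 3 (0.05 log units; within the scatter). For compound 3 the estimated value is 3800 nM, with an expected range of 1800 nM to 8000 nM.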

Compound 3, half-maximal inhibitory concentration: > 20000 nM
Compound 3: a limit, no number (the forecaster's own chance of this, stated with the estimate: 3%); middle value at least 5.2-fold (0.72 log units) away from the limit.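

In this assay, this methyl on the six-membered aromatic ring with 2 nitrogen matters, since hydrogen in its place gives an at least 4.6-fold higher number from compound 2 to compound 3 (0.66 log units; beyond the scatter). The fluoro step stayed within the scatter, so this is the first single change shown that moves the result beyond it. The value of compound 3 is a limit, not a number: the limit of > 20000 nM in this assay, at which 1 of the 3 values shown sits.

The compounds shown leave open whether an ethyl group or an amine at this position would keep the level of compound 2. They also leave open whether losing the methyl has the same effect without the fluoro.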